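A few compounds are considered here, and "the series" means these few. Any claim that something is new, unique, unknown or untested is made for them only; others in the source may bear on it.

Of the compounds shown here, three that share one core have been tested in a functional assay on the whole organism (Pleural cavity) for inhibition, with Rattus norvegicus as the target, at a dose of 25 mg/kg; on this read-out lower numbers stand for less inhibition and higher numbers for more inhibition at the one dose given (going by the name of the read-out). Compound 1 `CC1(Sc2ccccc2)C(=O)N(c2ccccc2)c2ncccc21` carries a phenylsulfanyl group on a saturated ring carbon and gives 0%. Compound 2 `CCC1(C)C(=O)N(c2ccccc2)c2ncccc21` has ethyl at that place and gives 12%. Compound 3 `CC1(F)C(=O)N(c2ccccc2)c2ncccc21` has fluoro there and gives 35%, the highest of the three numbers, since both a number 23 percentage points higher from compound 2 to compound 3 (beyond the scatter) and a number 35 percentage points higher from compound 1 to compound 3 (beyond the scatter) lie beyond the scatter.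

Compound 4 `CCCCC1(C)C(=O)N(c2ccccc2)c2ncccc21` is the compound still to be measured: butyl in place of fluoro on a saturated ring carbon. The two measured steps that end at compound 3 bear directly on this change. The step of a number 23 percentage points higher from compound 2 to compound 3 (beyond the scatter) shows that putting fluoro in place of ethyl, a plain carbon chain, raised the read-out, and the step of a number 35 percentage points higher from compound 1 to compound 3 (beyond the scatter) shows the same direction from phenylsulfanyl. Butyl is a plain carbon chain like ethyl, so replacing fluoro with butyl is expected to move the number back down, toward or below what compound 2 gave. The expected step is a number 27 percentage points lower from compound 3 to compound 4 (beyond the scatter), downward and beyond the scatter. Compound 4 is therefore estimated to give 8% in this assay, with a range from 0% to 25%. Among the compounds with values here, no measured compound carries butyl, so the range is kept wide.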

Compound 4, a percentage reported as inhibition, in the whole organism at one dose (the size of the read-out at that dose, not a potency): 5%
For compound 4 the middle estimate is 3 percentage points above the measured one; low and high end bracket the measured number.
By their numbers in this assay, from the lowest: compounds 1, 4 and 2 (each within the scatter of the next, the first and the last beyond it); then compound 3.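

The step of a number 30 percentage points lower from compound 3 to compound 4 (beyond the scatter) in this assay shows that a chain longer than ethyl on this saturated ring carbon also stands well under fluoro, so the low number seen with ethyl is not special to that one chain. Going from ethyl to butyl gives a number 7 percentage points lower from compound 2 to compound 4 (within the scatter), and butyl compared with phenylsulfanyl gives a number 5 percentage points higher from compound 1 to compound 4 (within the scatter), so neither step separates butyl from the group it replaces, although the ethyl and phenylsulfanyl compounds differ from each other by more than the scatter. Among the four groups at this position, fluoro alone stands clearly apart, and no measurement here explains why that is so.

The compounds shown leave open whether the higher number belongs to fluoro alone or would also appear with a chlorine atom, a hydroxyl group or an amine on this saturated ring carbon. They also leave open what a plain hydrogen or a methyl group would give at this place, and whether a chain longer than butyl would read any differently.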